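Ester Variation on a Shared Core: Expecting Compound 4

This account rests on a few compounds, and the source may have more. Where it says the series, first, only, none or still open, it means among the compounds named here.

Measured compounds:
compound 1 `C=C1C(=O)[C@@]23C(=O)OC[C@]4(C(=O)CCC(C)(C)[C@H]4C=O)[C@@H]2CC[C@@H]1[C@H]3OC(=O)CC` with 1780 nM
compound 2 `C=C1C(=O)[C@@]23C(=O)OC[C@]4(C(=O)CCC(C)(C)[C@H]4C=O)[C@@H]2CC[C@@H]1[C@H]3OC(=O)c1ccc(OC)cc1` with 1870 nM
compound 3 `C=C1C(=O)[C@@]23C(=O)OC[C@]4(C(=O)CCC(C)(C)[C@H]4C=O)[C@@H]2CC[C@@H]1[C@H]3OC(=O)c1ccc(F)cc1` with 3960 nM

In a functional assay on MGC-803 cells (Homo sapiens) for cytotoxicity, read by MTT assay, with a stated time of 72 h (on this read-out higher numbers stand for weaker inhibition and lower numbers for stronger inhibition), compound 2 stands second highest of the three numbers; compound 1 sits within the scatter of it, as a 1.1-fold higher number from compound 1 to compound 2 (0.02 log units; within the scatter) shows, while compound 3 lies beyond it, as a 2.1-fold higher number from compound 2 to compound 3 (0.33 log units; beyond the scatter) shows. Compound 4 `C=C1C(=O)[C@@]23C(=O)OC[C@]4(C(=O)CCC(C)(C)[C@H]4C=O)[C@@H]2CC[C@@H]1[C@H]3OC(=O)c1ccccc1Cl` has not yet been measured. The change from compound 2 is 2-chlorophenyl in place of 4-methoxyphenyl on a carbonyl carbon.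

For the measured compounds named here, two measured steps bear on this. Replacing the ethyl ester by an aryl ester left the number within the scatter in a 1.1-fold higher number from compound 1 to compound 2 (0.02 log units; within the scatter) but gave a modest rise in a 2.2-fold higher number from compound 1 to compound 3 (0.35 log units; beyond the scatter), and moving from methoxy to a halogen on the aromatic ring gave a modest rise in a 2.1-fold higher number from compound 2 to compound 3 (0.33 log units; beyond the scatter). Going by the values given here, no measured compound carries a 2-chlorophenyl group, so the size of the step is uncertain. A modest weakening, or none beyond the scatter, is expected for compound 4 in this assay, with the step estimated as a 1.5-fold higher number from compound 2 to compound 4 (0.18 log units; within the scatter). Compound 4 is therefore estimated at 2800 nM, with a range from 1400 nM to 6000 nM.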

Compound 4, half-maximal inhibitory concentration: 2660 nM
Estimate against measurement, compound 4: 1.1-fold (0.02 log units) above; measured number inside the range.
By their numbers in this assay, from the lowest: compounds 1, 2, 4 and 3 (each within the scatter of the next, the first and the last beyond it).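

In this assay, the 2-chlorophenyl ester could not be separated from any of the three earlier esters: the values stay within the scatter for the change from 4-methoxyphenyl (a 1.4-fold higher number from compound 2 to compound 4 (0.15 log units; within the scatter)), from 4-fluorophenyl (a 1.5-fold lower number from compound 3 to compound 4 (0.17 log units; within the scatter)) and from ethyl (a 1.5-fold higher number from compound 1 to compound 4 (0.17 log units; within the scatter)). Compound 4 thus overlaps both compound 1 and compound 3, although those two lie beyond the scatter of each other, so the modest gap seen earlier does not divide these esters into two clear groups. Nothing shown here accounts for these numbers.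

From the compounds shown here alone, all four esters span only a narrow range on the shared core, so it remains open whether any other ester at this position would give a larger change. An unsubstituted phenyl, a longer alkyl chain, or an aryl ring carrying an amine or a carboxylic acid would test this.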